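Working notes: from compound 3 to compound 4

A few compounds are considered here, and "the series" means these few. Any claim that something is new, unique, unknown or untested is made for them only; others in the source may bear on it.

Values in an ADME assay on HEK293 cells (Homo sapiens) for cytotoxicity, read by CCK-8 assay, with a stated time of 48 h (a higher number here means a weaker inhibitor, a lower number a stronger inhibitor), for the measured compounds:
- compound 1 `COc1ccc(/C=C\c2cc(OC)c(OC)c(OC)c2)cc1OCc1ccc(CN2CCCC[C@@H]2C(=O)O)cc1` gives 42000 nM
- compound 2 `COc1ccc(/C=C\c2cc(OC)c(OC)c(OC)c2)cc1OCc1ccc(CN2CC[C@H](C(=O)O)C2)cc1` gives > 50000 nM as a limit
- compound 3 `COc1ccc(/C=C\c2cc(OC)c(OC)c(OC)c2)cc1OCc1ccc(CN2CC(C(=O)O)C2)cc1` gives > 50000 nM as a limit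

Compound 3 gives only a limit in this assay (> 50000 nM), not a number. It stands at the limit of > 50000 nM in this assay, at which 2 of the 3 values shown sit, and has no readable position against compound 2.

Compound 4 `COc1ccc(/C=C\c2cc(OC)c(OC)c(OC)c2)cc1OCc1ccc(CN2CC[C@@H](O)C2)cc1` has 3-hydroxypyrrolidin-1-yl in place of 3-carboxyazetidin-1-yl on a saturated chain carbon bound to an aromatic carbon.

Among the compounds with values here, three measured steps bear on this, and each swaps one carboxy-bearing group for another. The first is an at least 1.1-fold higher number from compound 1 to compound 2 (0.07 log units; that floor lies within the scatter) and the second is an at least 1.1-fold higher number from compound 1 to compound 3 (0.07 log units; that floor lies within the scatter) while the third is a step that the two limits leave unreadable from compound 2 to compound 3 and none of them takes the carboxy group away. Compound 4 alone lacks that group, so these steps do not size the change directly.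

Within the data shown here, with compound 1 at 42000 nM as the only true number so far, a move to a lower number is expected, though only loosely. The estimate therefore means an at least 5.0-fold lower number from compound 3 to compound 4 (0.69 log units; beyond the scatter) as an expected step. For compound 4 the expected value is 10000 nM (estimated range 800 nM to 50000 nM).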

Compound 4, half-maximal inhibitory concentration: > 50000 nM
Compound 4: only a limit was reported; the forecaster's own chance of this, stated with the estimate: 25%; middle value at least 5.0-fold (0.69 log units) from the limit.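

In this assay compound 4 gives > 50000 nM, which is a limit and not a number. Within the data shown here, compound 4 is the first compound here whose group on the saturated chain carbon bound to an aromatic carbon carries no carboxy group, and with 3-hydroxypyrrolidin-1-yl in that place the reading still does not become a number: the limit of > 50000 nM in this assay, at which 3 of the 4 values shown sit. The one readable step, an at least 1.1-fold higher number from compound 1 to compound 4 (0.07 log units; that floor lies within the scatter), gives no order, and the steps from compound 3 to compound 4 and from compound 2 to compound 4 cannot be read, since both ends of each are limits.

The compounds shown leave open how far the true values of compound 2, compound 3 and compound 4 lie from one another, so the carboxy group and the hydroxy group cannot yet be sized against each other. They also leave open whether a different group in this place, such as a 3-aminopyrrolidin-1-yl with its primary amine or a morpholine, would give a true number in this assay.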